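The compounds below may be only part of what the source reports. "The series", "measured", "known", "first", "only" and "open" are said of these compounds alone.

Of the compounds shown here, three have so far been measured in a functional assay (blood) for inhibition, with Homo sapiens as the target; on this read-out higher numbers stand for weaker inhibition and lower numbers for stronger inhibition. Compound 1 `C/C(=N\OCCSc1nnc(C)s1)c1ccc(Sc2cc(F)cc(C3CCOCC3)c2)cc1` gives 230 nM, the highest of the three numbers. Compound 2 `C/C(=N\OCC(O)CO)c1ccc(S(=O)(=O)c2cccc(C3CCOCC3)c2)cc1` gives 160 nM, which lies within the scatter of compound 1, so the two cannot be ranked. Compound 3 `COC1(c2csc(Sc3ccc4c(c3)OCC/C4=N\OCC#N)c2)CCOCC1` gives 60 nM, and its gap to compound 1 lies beyond the scatter. Compound 4 `C/C(=N\OC(C)C)c1ccc(Sc2cc(F)cc(C3CCOCC3)c2)cc1` has not been measured. It differs from compound 1 in one place: isopropyl in place of 2-((5-methyl-1,3,4-thiadiazol-2-yl)sulfanyl)ethyl on an oxygen. Going by the values given here, no measured pair shows a change of this kind, so there is nothing to lean on for the size of the step. A small change, if any beyond the scatter, is expected, and the step is estimated as a 1.5-fold higher number from compound 1 to compound 4 (0.18 log units; within the scatter). Compound 4 is therefore expected to give about 350 nM, within a range from 100 nM to 1200 nM.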

Compound 4, half-maximal inhibitory concentration: 920 nM
Estimate against measurement, compound 4: 2.6-fold (0.42 log units) below; low and high end bracket the measured number.
By their numbers in this assay, from the lowest: compound 3; then compounds 2 and 1 (each within the scatter of the next); then compound 4.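

The group on this oxygen matters: in this assay, isopropyl in place of 2-((5-methyl-1,3,4-thiadiazol-2-yl)sulfanyl)ethyl gives a 4.0-fold higher number from compound 1 to compound 4 (0.60 log units; beyond the scatter), so inhibition weakens beyond the scatter. This single pair cannot separate the five-membered aromatic ring from the chain that carries it, since both leave together. Nothing measured here explains the step. Still open, from the compounds shown here alone, is whether a longer plain carbon chain on this oxygen would restore the lost inhibition without the ring. An amine or a carboxylic acid at the end of such a chain is equally untested in the compounds shown.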